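Removing the Methyl from the Piperidine Nitrogen

The compounds below may be only part of what the source reports. "The series", "measured", "known", "first", "only" and "open" are said of these compounds alone.

Compound 1, `Cc1ccc(CNC(=O)c2cccc(C(C)Oc3ccnc(Nc4cnn(C5CCN(C)CC5)c4)c3)c2)cc1`, gives 8900 nM in a functional assay on NCI-H3122 cells (Homo sapiens) for antiproliferative activity, read by MTT assay, with a stated time of 48 h; a lower number here means a stronger inhibitor, a higher number a weaker inhibitor.
Compound 2, `COc1ccc(CNC(=O)c2cccc(C(C)Oc3ccnc(Nc4cnn(C5CCN(C)CC5)c4)c3)c2)cc1OC`, gives 14800 nM in this assay.

Compound 2 stands at the higher of the two numbers in this assay, but the step of a 1.7-fold higher number from compound 1 to compound 2 (0.22 log units; within the scatter) lies within the scatter of repeated measurements, so the two compounds cannot be ordered against each other on these data.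

Compound 3, `COc1ccc(CNC(=O)c2cccc(C(C)Oc3ccnc(Nc4cnn(C5CCNCC5)c4)c3)c2)cc1OC`, differs from compound 2 in one place: hydrogen in place of methyl on an amine nitrogen in a ring. Among the measured compounds shown here, the two measured compounds share this part of the molecule unchanged, so no measured step bears on it. For the measured compounds named here, the only step known, from compound 1 to compound 2, concerns the aryl group on the saturated chain carbon bound to the amide-type nitrogen, a different part of the molecule, and it stayed within the scatter.

With nothing to draw on, the expectation for compound 3 in this assay is no step beyond the scatter, a 1.1-fold lower number from compound 2 to compound 3 (0.06 log units; within the scatter). Compound 3 is therefore estimated at 13000 nM, with a range from 5000 nM to 35000 nM.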

Compound 3, half-maximal inhibitory concentration: 47200 nM
Compound 3: middle estimate off by 3.6-fold (0.56 log units), on the low side, outside the stated range (above it).
By their numbers in this assay, from the lowest: compounds 1 and 2 (each within the scatter of the next); then compound 3.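

In this assay the change from the 1-methylpiperidin-4-yl group to piperidin-4-yl, which puts a hydrogen in place of methyl on the amine nitrogen in the ring, gives a 3.2-fold higher number from compound 2 to compound 3 (0.50 log units; beyond the scatter) and so makes the compound a weaker inhibitor, by a modest step. Among the compounds shown here, this amine nitrogen is therefore the first place in these compounds where a change moves the number beyond the scatter, and the change involved is the loss of just one carbon atom; the earlier step, a 1.7-fold higher number from compound 1 to compound 2 (0.22 log units; within the scatter) at the aryl group on the saturated chain carbon, stayed within the scatter and gave no such reading. Nothing measured here offers an explanation for the size or direction of this new step.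

As far as these compounds go, whether the same change would give a similar step with the 4-methylphenyl group of compound 1 remains open. So does the question of what a larger group on this amine nitrogen, such as ethyl or acetyl, would do to the number, and whether the methyl is the best choice at this position or simply better than hydrogen.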